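The source may report more compounds than this note shows. Statements on the series, on what has been measured and on what is new or still open speak of the compounds shown alone.

Of the compounds shown here, two from this set have been measured in an assay for inhibition of 17-beta-hydroxysteroid dehydrogenase type 1 (Homo sapiens), tested at 1 uM (on this read-out higher numbers stand for more inhibition at the one concentration tested (going by the name of the read-out) and lower numbers for less inhibition), so far. Compound 1, `Cc1nnc(NC(=O)c2c(O)ccc3cc(-c4cccc(O)c4)ccc23)s1`, carries an amide link between its shared core and a five-membered heteroaromatic ring; in this assay compound 1 gives 73%. Compound 2, `Cc1ccc(S(=O)(=O)c2c(O)ccc3cc(-c4cccc(O)c4)ccc23)cc1`, keeps the same core but replaces the amide link with a sulfonyl group carrying a 4-methylphenyl ring; in this assay compound 2 gives 75%. The two values lie within the usual scatter of each other, so compound 2 stands level with compound 1 on the numbers available, and nothing separates the two beyond repeat-to-repeat noise.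

Compound 3, `O=S(=O)(c1ccccc1)c1c(O)ccc2cc(-c3cccc(O)c3)ccc12`, has not yet been measured. It differs from compound 2 in a single place: hydrogen in place of methyl on an aromatic carbon. The change removes one carbon and leaves the rest of the molecule untouched. For the measured compounds named here, with no comparable step between measured compounds to lean on, the expectation rests on the smallness of the change alone, and the step of a number 3 percentage points lower from compound 2 to compound 3 (within the scatter) is expected to stay within the scatter. Compound 3 is therefore estimated to give about 72%, most likely between 55% and 85%.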

Compound 3, a percentage reported as inhibition, at one concentration (the size of the read-out at that concentration, not a potency): 33%
Compound 3: the middle estimate sits 39 percentage points above what was measured, and the stated range ends above it.
By their numbers in this assay, from the lowest: compound 3; then compounds 1 and 2 (each within the scatter of the next).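

In this assay the change from 4-methylphenyl to phenyl gives a number 42 percentage points lower from compound 2 to compound 3 (beyond the scatter), so at this place, para to a large group, the read-out depends strongly on a single carbon. Compound 3 also stands apart from the amide-linked compound, with a number 40 percentage points lower from compound 1 to compound 3 (beyond the scatter), which shows that the sulfonyl link alone does not secure a number level with those of compound 1 and compound 2. Nothing measured here tells why the loss of one methyl makes so large a difference.

The compounds shown leave open whether methyl is specifically needed at this ring carbon, or whether another group there, such as an ethyl, a chlorine, a methoxy group or an amine, would keep or raise the number seen with compound 2. On these data alone, the step also rests on one pair of compounds at one concentration, so it remains open whether removing the methyl would cost as much on a different core, and how the change would appear as a potency.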